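Compound 3 to Compound 4: Losing the Carboxy Group

A few compounds are considered here, and "the series" means these few. Any claim that something is new, unique, unknown or untested is made for them only; others in the source may bear on it.

Three compounds share one core and differ in the carboxy-bearing ring on a saturated chain carbon bound to an aromatic carbon: compound 1 (`COc1ccc(/C=C\c2cc(OC)c(OC)c(OC)c2)cc1OCc1ccc(CN2CCCC[C@H]2C(=O)O)cc1`), compound 2 (`COc1ccc(/C=C\c2cc(OC)c(OC)c(OC)c2)cc1OCc1ccc(CN2CC(C(=O)O)C2)cc1`) and compound 3 (`COc1ccc(/C=C\c2cc(OC)c(OC)c(OC)c2)cc1OCc1ccc(CN2CC[C@@H](C(=O)O)C2)cc1`). In an ADME assay on HEK293 cells (Homo sapiens) for cytotoxicity, read by CCK-8 assay, with a stated time of 48 h (on this read-out lower numbers stand for stronger inhibition and higher numbers for weaker inhibition), compound 1 gives > 50000 nM, which is a limit of the assay and not a number. Compound 2 gives > 50000 nM, again a limit. Within the data shown here, compound 3 gives 27000 nM, the only actual number of the three.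

Compound 4 (`COc1ccc(/C=C\c2cc(OC)c(OC)c(OC)c2)cc1OCc1ccc(CN2CCCCC2C(=O)NCCN)cc1`) changes that same place: 2-((2-aminoethyl)carbamoyl)piperidin-1-yl in place of 3-carboxypyrrolidin-1-yl on a saturated chain carbon bound to an aromatic carbon. The entering 2-((2-aminoethyl)carbamoyl)piperidin-1-yl group has no carboxy group, whereas all three measured compounds do.

Among the measured compounds shown here, two measured steps bear on this change: an at least 1.8-fold lower number from compound 1 to compound 3 (0.26 log units; that floor lies within the scatter) and an at least 1.8-fold lower number from compound 2 to compound 3 (0.26 log units; that floor lies within the scatter). Both only exchange one carboxy-bearing ring for another, so neither shows what happens when the carboxy group goes. The expectation therefore rests on thin ground, and its range must stay wide. The expected step is a 3.4-fold lower number from compound 3 to compound 4 (0.53 log units; beyond the scatter), a tentative move toward stronger inhibition in this assay. For compound 4 the estimated value is 8000 nM, with an expected range from 1000 nM to 50000 nM.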

Compound 4, half-maximal inhibitory concentration: > 50000 nM
Compound 4: only a limit was reported; the forecaster's own chance of this, stated with the estimate: 20%; middle value at least 6.2-fold (0.79 log units) away from the limit.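

In this assay compound 4 gives > 50000 nM, which is a limit of the assay and not a number. The change at this place reads as an at least 1.8-fold higher number from compound 3 to compound 4 (0.26 log units; that floor lies within the scatter), so compound 4, the first compound shown without a carboxy group here, gives no sign of the move toward stronger inhibition that a lower number would mean, although the size of the step remains uncertain. The steps to compound 4 from compound 1 and from compound 2 cannot be read, and most of this small series now rests on a single ceiling: the limit of > 50000 nM in this assay, at which 3 of the 4 values shown sit.

As far as these compounds go, compound 4 exchanges the five-membered ring for a six-membered one and the carboxy group for an aminoethyl amide in a single move, so the effect of each change on its own remains open. The five-membered ring carrying the same aminoethyl amide would address the ring, while a simple primary amide or a longer aminoalkyl chain on the six-membered ring would address the amine and its distance from the ring.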